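A few compounds are considered here, and "the series" means these few. Any claim that something is new, unique, unknown or untested is made for them only; others in the source may bear on it.

Measured compounds and their values:

Compound 1 `O=[N+]([O-])c1cc(C(F)(F)F)cc([N+](=O)[O-])c1Oc1ccc(Br)cc1/C=N\OCc1ccccc1` — in a functional assay on MCF7 cells (Homo sapiens) for antiproliferative activity, read by MTT assay, with a stated time of 48 h (on this read-out higher numbers stand for weaker inhibition and lower numbers for stronger inhibition), compound 1 gives 1150 nM.
Compound 2 `O=[N+]([O-])c1cc(C(F)(F)F)cc([N+](=O)[O-])c1Oc1ccc(Br)cc1/C=N\OCc1ccccc1F` — in this assay compound 2 gives 1120 nM.
Compound 3 `O=[N+]([O-])c1cc(C(F)(F)F)cc([N+](=O)[O-])c1Oc1c(Cl)cc(Cl)cc1/C=N\OCc1ccccc1` — in this assay compound 3 gives 1210 nM.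

Compounds 1 and 2 share one core; the change between them is fluoro in place of hydrogen on an aromatic carbon. The step it made is a 1.0-fold lower number from compound 1 to compound 2 (0.01 log units; within the scatter), so the two numbers are not distinguishable from one another in this assay.

Compound 3 carries a different core from compound 1; the difference between the two cores is not broken down here. Its value sits close to those of compounds 1 and 2, and all three numbers fall within the usual scatter of one another, so no ordering among them is supported.

Compound 4 `O=[N+]([O-])c1cc(C(F)(F)F)cc([N+](=O)[O-])c1Oc1c(Cl)cc(Cl)cc1/C=N\OCc1ccccc1F` is not yet measured in this assay. It differs from compound 3 by fluoro in place of hydrogen on an aromatic carbon. Going by the values given here, this is the same change as the one from compound 1 to compound 2, made on the core of compound 3: the place lines for the two changes read alike word for word.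

For compound 4 the step from compound 3 is expected to be about a 1.0-fold lower number from compound 3 to compound 4 (0.00 log units; within the scatter), resting on the earlier occurrence, which gave a 1.0-fold lower number from compound 1 to compound 2 (0.01 log units; within the scatter), with no visible effect on the number. The estimate for compound 4 in this assay is 1200 nM, expected to lie between 700 nM and 2100 nM, on the assumption that the change behaves on the core of compound 3 as it did on the core of compound 1; that assumption rests on a single prior pair.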

Compound 4, half-maximal inhibitory concentration: 800 nM
Estimate against measurement, compound 4: 1.5-fold (0.18 log units) above; the range from low to high includes it.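

In this assay the move from benzyl to 2-fluorobenzyl on the core of compound 3 gives a 1.5-fold lower number from compound 3 to compound 4 (0.18 log units; within the scatter) and so shows no effect that can be told apart from repeat measurement on this core. This does not show that the change is neutral on every core in the series, nor that the two cores respond identically, since the comparison rests on just two pairs, one place on the ring and a single assay. What can be said is that the change carries from one core to the other with no detectable difference between the two steps, and the reading is limited to that: the same change on two cores in this assay, a 1.0-fold lower number (0.01 log units; within the scatter) from compound 1 to compound 2 and a 1.5-fold lower number (0.18 log units; within the scatter) from compound 3 to compound 4, 1.5-fold (0.17 log units) apart, within the scatter of two such steps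

The compounds shown leave open how other groups on the same aromatic carbon would read, such as chloro, methoxy, an amine or a carboxylic acid, and whether fluoro on the other carbons of that ring would behave as it does here. Also open, going by these compounds, is whether replacing benzyl with a longer chain, or with a ring carrying a nitrogen atom, would produce a step beyond the scatter on either core.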